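A few compounds are considered here, and "the series" means these few. Any claim that something is new, unique, unknown or untested is made for them only; others in the source may bear on it.

Two compounds of the series have numbers in an assay on HEK293 cells for displacement of a labelled ligand from Melanocortin receptor 4 (Homo sapiens); a higher number here means a weaker inhibitor, a lower number a stronger inhibitor. Compound 1 `Cc1ccc(N2CCN(C(=O)[C@H]3[C@@H](c4ccc(Cl)cc4)CCN3C(C)C)CC2)c([C@@H](N)C(C)C)c1` gives 110 nM in this assay. Compound 2 `Cc1ccc(N2CCN(C(=O)[C@@H]3NCC[C@@H]3c3ccc(Cl)cc3)CC2)c([C@@H](N)C(C)C)c1` gives 52 nM in this assay, the lowest of the two numbers shown. Among the measured compounds shown here, the only measured step, a 2.1-fold lower number from compound 1 to compound 2 (0.33 log units; beyond the scatter), is hydrogen in place of isopropyl on an amine nitrogen in a ring. Compound 3 `Cc1ccc(N2CCN(C(=O)C3NCCC3c3ccc(Cl)cc3)CC2)c([C@@H](N)C(C)C)c1` differs from compound 2 in this way: the two compounds have the same atoms and bonds; at least one stereo element is drawn with a configuration in one of them and without one in the other: 2 of 3 stereo elements differ; a stereocentre at a saturated ring carbon is drawn R in compound 2 and without a configuration in compound 3; a stereocentre at a saturated ring carbon is drawn R in compound 2 and without a configuration in compound 3. For the measured compounds named here, no measured step bears on a drawn configuration being absent; the one step above concerns a different change and gives no guide here. With two stereocentres of compound 2 left without configuration in compound 3, a modest step towards a higher number is expected, a 1.6-fold higher number from compound 2 to compound 3 (0.21 log units; within the scatter), though a result within the scatter of compound 2 would not surprise. Compound 3 is therefore estimated at 85 nM in this assay, with a range of 35 nM to 250 nM.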

Compound 3, inhibition constant: 56 nM
The estimate for compound 3 lay 1.5-fold (0.18 log units) above the measured number; measured number inside the range.
By their numbers in this assay, from the lowest: compounds 2, 3 and 1 (each within the scatter of the next, the first and the last beyond it).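

In this assay, the series now has a reading on the two stereocentres at saturated ring carbons, where the earlier step covered only the substituent on the ring amine nitrogen: a 1.1-fold higher number from compound 2 to compound 3 (0.03 log units; within the scatter). With the same atoms and bonds, drawing both stereocentres as R or leaving them without a configuration gives numbers that cannot be told apart here. This does not show that configuration at these carbons is unimportant, and the comparison is limited by one fact: the fact that one of compounds 2 and 3 is drawn with a defined configuration and the other without, at the place where they differ.

As far as these compounds go, how any other single defined configuration at these two carbons would compare with that of compound 2 remains open. Also open, from the compounds shown here alone, is how a methyl or an acetyl group on the ring amine nitrogen would compare with the hydrogen and isopropyl seen so far.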